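From propyl to 4-methoxyphenyl on a shared core

The source may report more compounds than this note shows. Statements on the series, on what has been measured and on what is new or still open speak of the compounds shown alone.

- Compound 1 `Cc1nn(C)c2nc(NNC(=O)Nc3cc(Cl)nc(Cl)c3)cc(C3CC3)c12`: 80800 nM
- Compound 2 `CCCc1cc(NNC(=O)Nc2cc(Cl)nc(Cl)c2)nc2c1c(C)nn2C`: 40800 nM

Both values come from a functional assay on SW620/5-FU cells (Homo sapiens) for cytotoxicity, read by MTT assay, with a stated time of 48 h, in the presence of a further agent that is not named here; a higher number here means that more compound is needed for the effect, a lower number that less compound is needed. Within the data shown here, compound 2, at 40800 nM, lies within the scatter of compound 1, the only other compound measured so far, so the numbers do not separate the two.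

Compound 3 `COc1ccc(-c2cc(NNC(=O)Nc3cc(Cl)nc(Cl)c3)nc3c2c(C)nn3C)cc1` keeps the core of compound 2 and differs from it in one group: 4-methoxyphenyl in place of propyl on an aromatic carbon. In words, 4-methoxyphenyl stands in place of propyl on an aromatic carbon, opposite the ring nitrogen.

Among the measured compounds shown here, only one measured step bears on this carbon: propyl in place of cyclopropyl gave a 2.0-fold lower number from compound 1 to compound 2 (0.30 log units; within the scatter). For the measured compounds named here, no measured compound carries an aromatic ring there, so the data offer no direction for the new change, and the evidence is thin. Given that single step, no shift beyond the scatter is expected, though a wide margin is needed on either side. The step expected in this assay is a 1.0-fold lower number from compound 2 to compound 3 (0.01 log units; within the scatter). For compound 3 the estimated value is 40000 nM, with an expected range from 12000 nM to 120000 nM.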

Compound 3, half-maximal effective concentration: 9700 nM
Estimate against measurement, compound 3: 4.1-fold (0.62 log units) above, outside the stated range (below it).
By their numbers in this assay, from the lowest: compound 3; then compounds 2 and 1 (each within the scatter of the next).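

At this aromatic carbon, opposite the ring nitrogen, the earlier pair gave no separation, as cyclopropyl and propyl stood within the scatter of each other. In this assay, among these compounds, the change to 4-methoxyphenyl produces the first steps beyond the scatter, with a 4.2-fold lower number from compound 2 to compound 3 (0.62 log units; beyond the scatter) and an 8.3-fold lower number from compound 1 to compound 3 (0.92 log units; beyond the scatter), so the number does respond to what this carbon carries, at least when one six-membered aromatic ring of carbon only with a methoxy group enters in place of a small carbon group. Nothing measured here accounts for that shift, and the reason for it remains unknown.

The three compounds cannot separate the part played by the aromatic ring from that of its methoxy group, and a plain phenyl group or a 4-chlorophenyl group at this carbon would be needed to tell the two apart. They also leave open how a longer alkyl chain, an amine or a carboxylic acid would fare at this carbon, and whether the number can fall further than the 9700 nM of compound 3.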